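Removing the Methoxy and a Ring Nitrogen in Compound 3

The source may hold more compounds than are shown below. What is called first, only, known or untested is meant among the compounds shown, and "the series" means these compounds.

Compound 1 `COc1cc(Oc2ccc(NC(=O)Nc3cccc(C(F)(F)F)c3)cc2)ncn1` carries, on an oxygen on an aromatic ring, a 6-methoxypyrimidin-4-yl group. Within the data shown here, in an assay on isolated protein for inhibition of serine/threonine-protein kinase TNNI3K (Homo sapiens) (a lower number here means a stronger inhibitor, a higher number a weaker inhibitor), compound 1 gives 4000 nM, the highest of the two numbers known so far. Compound 2 `C[C@@H](O)CNc1cc(Oc2ccc(NC(=O)Nc3cccc(C(F)(F)F)c3)cc2)ncn1` differs from it only in the group on that ring: in this assay compound 2 gives 63 nM, and the step of a 63-fold lower number from compound 1 to compound 2 (1.80 log units; beyond the scatter) is large. Compound 3 `O=C(Nc1ccc(Oc2ccncc2)cc1)Nc1cccc(C(F)(F)F)c1` has not been measured. Its difference from compound 1 is pyridin-4-yl in place of 6-methoxypyrimidin-4-yl on an oxygen on an aromatic ring. Among the measured compounds shown here, no measured step matches this change; the one step known, from compound 1 to compound 2, shows only that changing the group on the ring on the oxygen can move the number a long way. Compound 3 removes the methoxy altogether rather than replacing it with the group that helped compound 2, so a smaller move in either direction is expected. Compound 3 is estimated at 2500 nM, with a range from 500 nM to 12000 nM, and the step of a 1.6-fold lower number from compound 1 to compound 3 (0.20 log units; within the scatter) is expected to stay close to or modestly below the number for compound 1.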

Compound 3, half-maximal inhibitory concentration: 50 nM
For compound 3 the middle estimate is 50-fold (1.70 log units) above the measured one, and the stated range ends above it.
By their numbers in this assay, from the lowest: compounds 3 and 2 (each within the scatter of the next); then compound 1.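

In this assay the step of an 80-fold lower number from compound 1 to compound 3 (1.90 log units; beyond the scatter) is large, and it shows that a low number at this position does not require the (2-hydroxypropyl)amino group that compound 2 carries. Compound 3 has no group at all in place of that amine or of the methoxy, yet compound 3 gives 50 nM and compound 2 gives 63 nM, two values within the scatter of each other. Two different changes to the group on the oxygen thus lead away from the high number of compound 1, so that number appears tied to 6-methoxypyrimidin-4-yl itself among these three compounds, though nothing shown explains the size of the step.

The change from compound 1 to compound 3 removes the methoxy and a ring nitrogen together, and only an unsubstituted pyrimidin-4-yl group or a methoxy on the pyridin-4-yl ring could separate the two. From the compounds shown here alone, it also remains open whether the (2-hydroxypropyl)amino group, or a longer amine chain, on the pyridin-4-yl ring would lower the number further or raise it.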